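The source may report more compounds than this note shows. Statements on the series, on what has been measured and on what is new or still open speak of the compounds shown alone.

In an assay on HEK293 cells for binding affinity to Urotensin-2 receptor (Homo sapiens), read by radioligand binding (on this read-out higher numbers stand for weaker inhibition and lower numbers for stronger inhibition), compound 1 `CN(C)CCCOc1ccc(CN2CC[C@H](NC(=O)c3ccccc3)C2)cc1` gives 2510 nM. Compound 2 `CN(C)CCCOc1ccc(CN2CC[C@H](NC(=O)c3ccncc3)C2)cc1` reaches only a limit of this assay, < 10000 nM. The change phenyl in place of pyridin-4-yl on a carbonyl carbon therefore shows a step that the limit leaves unreadable from compound 2 to compound 1, which stays unreadable because of the limit of < 10000 nM in this assay, at which 1 of the 3 values shown sits. Compound 3 `CC(C)C[C@H](NC(=O)c1ccncc1)C(=O)N[C@H]1CCN(Cc2ccc(OCCCN(C)C)cc2)C1` gives 2000 nM in this assay, a value within the scatter of compound 1; the difference between the core of compound 3 and the core of compound 2 is not broken down here. Compound 4 `CC(C)C[C@H](NC(=O)c1ccccc1)C(=O)N[C@H]1CCN(Cc2ccc(OCCCN(C)C)cc2)C1` carries the same change, (phenyl in place of pyridin-4-yl on a carbonyl carbon), on the core of compound 3. Among the measured compounds shown here, since the only measured instance of this change gives no readable size, the step from compound 3 to compound 4 is estimated as no change at the digits printed from compound 3 to compound 4 (within the scatter). Compound 4 is thus expected to give about 2000 nM in this assay, between 600 nM and 6500 nM.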

Compound 4, inhibition constant: 501 nM
Estimate against measurement, compound 4: 4.0-fold (0.60 log units) above, and the stated range ends above it.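

In this assay, phenyl in place of pyridin-4-yl on a carbonyl carbon gives a 4.0-fold lower number from compound 3 to compound 4 (0.60 log units; beyond the scatter), so on the core of compound 3 this change has a readable size beyond the scatter. On the core of compound 2 the same change cannot be read, because compound 2 stands only at a limit: the limit of < 10000 nM in this assay, at which 1 of the 4 values shown sits. This single readable step therefore shows what the change does on one core, but not whether it carries over to another core with the same size or direction.

The compounds shown leave open how a cyclohexyl or a thienyl group on the same carbonyl carbon would compare with phenyl and pyridin-4-yl. They also leave open the size of this change on any third core.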